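Aryl-amine variation in a dichlorophenyl-urea pyrimidine series

The compounds below may be only part of what the source reports. "The series", "measured", "known", "first", "only" and "open" are said of these compounds alone.

Measured so far:
compound 1 `COc1ccc(OC)c(Nc2cc(NC(=O)Nc3c(Cl)cccc3Cl)ncn2)c1`: 93.1%
compound 2 `COc1cc(Br)ccc1Nc1cc(NC(=O)Nc2c(Cl)cccc2Cl)ncn1`: 47.3%
compound 3 `COc1ccc(F)cc1Nc1cc(NC(=O)Nc2c(Cl)cccc2Cl)ncn1`: 73.1%

All three were run in a functional assay on NCI-H1581 cells (Homo sapiens) for inhibition, read by MTT assay, with a stated time of 48 h, tested at 10 uM; a lower number here means less inhibition, a higher number more inhibition at the concentration tested (going by the name of the read-out). Compound 3 sits second of the three numbers: compound 1 lies above it, a number 20 percentage points lower from compound 1 to compound 3 (beyond the scatter), and compound 2 lies below it, a number 25.8 percentage points higher from compound 2 to compound 3 (beyond the scatter). Both of those steps sit beyond the scatter and both are modest in size.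

Compound 4 `O=C(Nc1cc(Nc2ccc(F)c(Cl)c2)ncn1)Nc1c(Cl)cccc1Cl` is the next member. Its change relative to compound 3 is 3-chloro-4-fluorophenyl in place of 5-fluoro-2-methoxyphenyl on a nitrogen on an aromatic ring. Neither measured step repeats this change. The closest guidance is the loss of a methoxy group seen in going from compound 1 to compound 3, which lowered inhibition by a modest amount, and the halogen-only pattern of compound 2, which gave the lowest number in the set. Compound 4 carries no methoxy at all, so a modest drop from compound 3 is expected rather than a gain. The estimated step is a number 18.1 percentage points lower from compound 3 to compound 4 (beyond the scatter). For compound 4 the expected inhibition in this assay is 55%, with a range from 30% to 80%.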

Compound 4, a percentage reported as inhibition, at one concentration (the size of the read-out at that concentration, not a potency): 67%
Compound 4: the middle estimate sits 12 percentage points below what was measured; measured number inside the range.
By their numbers in this assay, from the lowest: compound 2; then compounds 4 and 3 (each within the scatter of the next); then compound 1.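

Compound 4 is the first member shown without a methoxy on this aryl group, and in this assay the exchange of 5-fluoro-2-methoxyphenyl for 3-chloro-4-fluorophenyl (a number 6.1 percentage points lower from compound 3 to compound 4 (within the scatter)) shows that, for this pair, a substantial reading on this nitrogen does not require that methoxy. The second step (a number 19.7 percentage points higher from compound 2 to compound 4 (beyond the scatter)) puts a methoxy-free group above the methoxy-bearing 4-bromo-2-methoxyphenyl, so among the compounds shown the presence of a methoxy does not by itself set the number, although compound 1, which carries two methoxy groups, remains the top reading of the set. No measurement is available that explains either step.

Each of these exchanges alters more than one substituent at once, so the separate contributions of the chloro, the fluoro and the methoxy remain unresolved, and a single-concentration reading leaves the potency of these compounds open. Also open, from the compounds shown here alone, is how this aryl group would respond to a morpholine, a carboxylic acid or a longer alkoxy chain such as butoxy in place of its halogens.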